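A few compounds are considered here, and "the series" means these few. Any claim that something is new, unique, unknown or untested is made for them only; others in the source may bear on it.

Compound 1 `CN(C)C(=O)c1cc2cnc(Nc3ccc(NC(=O)C4(C(=O)Nc5ccccc5F)CC4)cc3)nc2n1C1CCCC1`: 63.4%
Compound 2 `Nc1ccc(NC(=O)C2(C(=O)Nc3ccc(F)cc3)CC2)cc1F`: 21.7%
Compound 3 `CN(C)C(=O)c1cc2cnc(Nc3ccc(NC(=O)C4(C(=O)Nc5ccc(F)cc5)CC4)cc3F)nc2n1C1CCCC1`: 6.6%

In a functional assay on SiHa cells (Homo sapiens) for inhibition, read by CCK-8 assay, with a stated time of 72 h, tested at 1 uM (on this read-out higher numbers stand for more inhibition of growth at the one concentration tested and lower numbers for less inhibition of growth), compound 1 stands highest of the three, and both other compounds lie lower by more than the usual scatter. Compound 4 `CN(C)C(=O)c1cc2cnc(Nc3ccc(NC(=O)C4(C(=O)Nc5ccccc5)CC4)cc3)nc2n1C1CCCC1` is compound 1 with hydrogen in place of fluoro on an aromatic carbon, ortho to a large group: hydrogen in place of fluoro on an aromatic carbon. Among the compounds with values here, no two measured compounds differ in one place only, so no measured step shows what this swap does. A single small atom is changing, so only a small loss is expected, possibly none beyond the scatter. The expected change is a number 7.4 percentage points lower from compound 1 to compound 4 (within the scatter). For compound 4 the estimated value is 56%, with an expected range of 32% to 75%.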

Compound 4, percent growth inhibition at one concentration: 58%
For compound 4 the middle estimate is 2 percentage points below the measured one, and the stated range covers the measured number.
By their numbers in this assay, from the lowest: compound 3; then compound 2; then compounds 4 and 1 (each within the scatter of the next).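

In this assay, hydrogen in place of fluoro on an aromatic carbon, ortho to a large group, gives a number 5.4 percentage points lower from compound 1 to compound 4 (within the scatter), so at this single concentration the growth inhibition of compound 1 does not depend on the fluoro. Within the data shown here, this is the first direct reading at this position, and it shows that the plain phenyl holds up as well as the 2-fluorophenyl. No measured property of these compounds bears on this result.

Going by these compounds, whether an amine, a methoxy group or a carboxylic acid at this position would also be tolerated remains open. So does whether the two compounds would still match at other concentrations.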